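The source may report more compounds than this note shows. Statements on the series, on what has been measured and on what is new or still open speak of the compounds shown alone.

Working notes on the series

Compound 1 `COC(=O)[C@@]1(C)CCC=C2[C@@H]1CC[C@@H](C)[C@]2(C)Cc1c[nH]c2ccc(Cl)cc12` and compound 2 `COC(=O)[C@@]1(C)CCC=C2[C@@H]1CC[C@@H](C)[C@]2(C)Cc1c[nH]c2ccc(F)cc12` share one core and differ only in a single substituent. In a functional assay on HBL-100 cells (Homo sapiens) for inhibition, read by sulforhodamine B assay, with a stated time of 48 h (on this read-out lower numbers stand for stronger inhibition of growth and higher numbers for weaker inhibition of growth), compound 1 gives 17000 nM, and compound 2 gives 4800 nM. The change between them is fluoro in place of chloro on an aromatic carbon, and the step it made is a 3.5-fold lower number from compound 1 to compound 2 (0.55 log units; beyond the scatter).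

Compound 3 `COC(=O)[C@@]1(C)CC[C@@H]2C3=C1CC[C@@H](C)[C@]3(C)C[C@@H]1c3cc(Cl)ccc3N[C@H]21` is built from the same atoms as compound 1, joined differently; the difference between the two cores is not broken down here. In this assay compound 3 gives 28000 nM. The gap between the values of compound 3 and compound 1 lies within the usual scatter, so nothing is read into it, whereas the gap between compound 3 and compound 2 lies beyond the scatter.

Compound 4 `COC(=O)[C@@]1(C)CC[C@@H]2C3=C1CC[C@@H](C)[C@]3(C)C[C@@H]1c3cc(F)ccc3N[C@H]21` has not yet been measured in this assay. Its difference from compound 3 is fluoro in place of chloro on an aromatic carbon. This is the same kind of change as that from compound 1 to compound 2, though not the same: the ring carrying the substituent is part of a fused or bridged system of five rings in compound 3 and compound 4, against two rings in compound 1 and compound 2. The expectation is a step of a 2.9-fold lower number from compound 3 to compound 4 (0.47 log units; beyond the scatter), resting on the earlier step of a 3.5-fold lower number from compound 1 to compound 2 (0.55 log units; beyond the scatter) applied to compound 3 at 28000 nM. That expectation is tempered somewhat: the place differs, and this change has been seen only once. For compound 4 the estimated value in this assay is 9500 nM, expected to fall between 4000 nM and 25000 nM.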

Compound 4, concentration for 50% growth inhibition: 18000 nM
Estimate against measurement, compound 4: 1.9-fold (0.28 log units) below; measured number inside the range.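

In this assay, fluoro in place of chloro on the core of compound 3 gives a 1.6-fold lower number from compound 3 to compound 4 (0.19 log units; within the scatter), a step within the scatter, whereas the same change on the core of compound 1 gave a 3.5-fold lower number from compound 1 to compound 2 (0.55 log units; beyond the scatter), a step beyond it. Taken on their own, these results might suggest that the change acts differently on the two cores, but the two steps cannot be told apart: the same change on two cores in this assay, a 3.5-fold lower number (0.55 log units; beyond the scatter) from compound 1 to compound 2 and a 1.6-fold lower number (0.19 log units; within the scatter) from compound 3 to compound 4, 2.3-fold (0.36 log units) apart, within the scatter of two such steps. Going by these compounds alone, this shows that the results on the two cores are compatible with one another, but it does not show that the change carries over with a fixed size, or that the core alters it, since each core offers only a single pair.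

As far as these compounds go, all four compounds carry chloro or fluoro on the aromatic ring, so the effect of methoxy, nitrile or trifluoromethyl at that place remains open on both cores. All four also keep the methyl ester, which leaves open how a carboxylic acid or an amide in its place would read in this assay, and whether such a group would behave alike on the two cores.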